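Replacing the Double-Bonded Chain of Compound 3

This account rests on a few compounds, and the source may have more. Where it says the series, first, only, none or still open, it means among the compounds named here.

In a functional assay on PC-3 cells (Homo sapiens) for antiproliferative activity, read by sulforhodamine B assay (on this read-out higher numbers stand for weaker inhibition of growth and lower numbers for stronger inhibition of growth), compound 3 (`CC(C)=CCOc1cccc(O)c1C(=O)/C=C/c1ccc(O)cc1`) gives > 30000 nM, a limit and not a number. Compound 1 (`COc1cccc(OCCC(C)(C)C)c1C(=O)/C=C/c1ccc(O)cc1`) gives > 30000 nM, likewise a limit. Compound 2 (`CC(C)(C)CCOc1cccc(O)c1C(=O)/C=C/c1ccc(O)cc1`) gives a true number, 3220 nM. The move to compound 4 (`CCC(CC)COc1cccc(O)c1C(=O)/C=C/c1ccc(O)cc1`) is pentan-3-yl in place of 2-methylprop-1-en-1-yl on a saturated chain carbon bound to an oxygen on an aromatic ring, with pentan-3-yl in place of 2-methylprop-1-en-1-yl. Going by the values given here, the closest precedent is an at least 9.3-fold higher number from compound 2 to compound 3 (0.96 log units; beyond the scatter), where neopentyl gave way to 2-methylprop-1-en-1-yl. The other step, an at least 9.3-fold lower number from compound 1 to compound 2 (0.96 log units; beyond the scatter), concerns the methyl on an oxygen, and compound 4 keeps the hydrogen there. Like compound 2, compound 4 has a saturated branched chain, so much of that loss should return. A lower number is expected, an at least 5.0-fold lower number from compound 3 to compound 4 (0.69 log units; beyond the scatter). The estimate for compound 4 is 6000 nM, within an expected range of 2000 nM to 25000 nM.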

Compound 4, concentration for 50% growth inhibition: 3390 nM
Compound 4: middle estimate off by 1.8-fold (0.25 log units), on the high side; the measured number falls inside the stated range.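

With pentan-3-yl in place of 2-methylprop-1-en-1-yl, the result is an at least 8.8-fold lower number from compound 3 to compound 4 (0.94 log units; beyond the scatter), and that size is only a bound, since compound 3 stands at a limit: the limit of > 30000 nM in this assay, at which 2 of the 4 values shown sit. A second saturated branched chain now gives a true number, and it does not separate from neopentyl, with a 1.1-fold higher number from compound 2 to compound 4 (0.02 log units; within the scatter).

The leaving and entering groups differ both in the double bond and in carbon count, so the compounds shown do not tell which of the two matters. On these data alone, what an amine or a carboxylic acid at the end of this chain would do also remains open.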